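This account rests on a few compounds, and the source may have more. Where it says the series, first, only, none or still open, it means among the compounds named here.

Measured compounds:
Compound 1, `Cc1ccc(-c2nn(-c3ccccc3)cc2-c2nc3ccccc3n2S(=O)(=O)c2ccc(F)cc2)cc1`, gives 3240 nM in a functional assay on A549 cells (Homo sapiens) for antiproliferative activity, read by MTT assay, with a stated time of 24 h; a lower number here means a stronger inhibitor, a higher number a weaker inhibitor.
Compound 2, `Cc1ccc(-c2nn(-c3ccccc3)cc2-c2nc3ccccc3n2S(=O)(=O)c2ccc(Cl)cc2)cc1`, gives 3550 nM in this assay.
Compound 3, `O=S(=O)(c1ccc(F)cc1)n1c(-c2cn(-c3ccccc3)nc2-c2ccc(C(F)(F)F)cc2)nc2ccccc21`, gives 1740 nM in this assay.

Compounds 1 and 2 share a core and differ in one place: chloro in place of fluoro on an aromatic carbon. That change made the step of a 1.1-fold higher number from compound 1 to compound 2 (0.04 log units; within the scatter), so the two numbers cannot be told apart in this study. Compound 3 differs from compound 1 by trifluoromethyl in place of methyl on an aromatic carbon, and the step there is a 1.9-fold lower number from compound 1 to compound 3 (0.27 log units; within the scatter). Compound 3 stands at the lowest of the three numbers, but its gap to compound 1 is within the scatter, and only its gap to compound 2 lies beyond it, so no ranking is claimed here.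

Compound 4, `O=S(=O)(c1ccc(Cl)cc1)n1c(-c2cn(-c3ccccc3)nc2-c2ccc(C(F)(F)F)cc2)nc2ccccc21`, has not yet been measured in this assay. Among the measured compounds shown here, it differs from compound 3 by chloro in place of fluoro on an aromatic carbon, which is the same change as the one between compound 1 and compound 2, at a place described in the same words. For the measured compounds named here, the same change, on the core of compound 1, gave the step of a 1.1-fold higher number from compound 1 to compound 2 (0.04 log units; within the scatter), and this is the only evidence available for it; there is no other pair to check it against.

On that basis the step from compound 3 to compound 4 is expected to be small, a 1.1-fold higher number from compound 3 to compound 4 (0.04 log units; within the scatter), resting on the step of a 1.1-fold higher number from compound 1 to compound 2 (0.04 log units; within the scatter). Compound 4 is accordingly expected to give about 1900 nM, most likely between 1000 nM and 3800 nM.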

Compound 4, half-maximal inhibitory concentration: 2560 nM
Compound 4: middle estimate off by 1.3-fold (0.13 log units), on the low side, within the range that was stated.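

In this assay, chloro in place of fluoro gives a 1.5-fold higher number from compound 3 to compound 4 (0.17 log units; within the scatter) on the second core, and this step agrees with the one on the core of compound 1: the same change on two cores in this assay, a 1.1-fold higher number (0.04 log units; within the scatter) from compound 1 to compound 2 and a 1.5-fold higher number (0.17 log units; within the scatter) from compound 3 to compound 4, 1.3-fold (0.13 log units) apart, within the scatter of two such steps. Trifluoromethyl in place of methyl now has a second reading as well, a 1.4-fold lower number from compound 2 to compound 4 (0.14 log units; within the scatter), and it agrees with the first in the same way: the same change on two cores in this assay, a 1.9-fold lower number (0.27 log units; within the scatter) from compound 1 to compound 3 and a 1.4-fold lower number (0.14 log units; within the scatter) from compound 2 to compound 4, 1.3-fold (0.13 log units) apart, within the scatter of two such steps. Among the compounds shown here, both changes therefore carried across these two cores with no gap that can be told from the scatter, but every step involved is itself within the scatter, so the four compounds show only that the steps stay small on both cores, and they neither fix a true size for either change nor establish that the agreement would hold on a third core.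

On these data alone, the four compounds vary only between fluoro and chloro on the arylsulfonyl group and between methyl and trifluoromethyl on the other aryl group, so what a methoxy group, an amine or a carboxylic acid would do at either place remains open. Whether the steps would read the same in a different cell line also remains open, as only this one assay is shown.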